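The source may hold more compounds than are shown below. What is called first, only, known or untested is meant among the compounds shown, and "the series" means these compounds.

Measured compounds:
- compound 1, `O=C(CSc1nc2ccccc2[nH]1)c1ccc(O)cc1`: in a functional assay on HT-29 cells (Homo sapiens) for inhibition, read by flow cytometry, tested at 10 uM (on this read-out higher numbers stand for more inhibition at the one concentration tested (going by the name of the read-out) and lower numbers for less inhibition), compound 1 gives "not active" (no number reported)
- compound 2, `Cc1ccc(C(=O)CSc2nc3ccccc3[nH]2)cc1`: compound 2 gives 40%
- compound 3, `COc1ccccc1C(=O)CSc1nc2ccccc2[nH]1`: compound 3 gives 34.9%

All three share one core, a ketone carrying a phenyl ring, and differ only in the group on that ring. Compound 1, with a hydroxy group, gave no number and was simply reported as not active. Compound 2 and compound 3 both gave numbers, and these two numbers lie within the usual scatter of each other, so in this assay compound 3 cannot be told apart from compound 2. Against that, compound 1 stands out only in that no single number was obtained for it.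

Compound 4, `O=C(CSc1nc2ccccc2[nH]1)c1ccccc1`, is the next compound to be tested. Compared with compound 3 the change is hydrogen in place of methoxy on an aromatic carbon. For the measured compounds named here, no measured pair shows what such a removal does here. Since compound 2 and compound 3, with different groups on the ring, give numbers within the scatter of each other, taking the group away altogether is not expected to move the number far in either direction. In this assay compound 4 is therefore expected to give about 30%, with a likely range from 10% to 50%. The step expected is a number 4.9 percentage points lower from compound 3 to compound 4 (within the scatter), no larger than the usual scatter.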

Compound 4, a percentage reported as inhibition, at one concentration (the size of the read-out at that concentration, not a potency): "not active" (no number reported)
No number was reported for compound 4, and the estimate cannot be compared.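

For the compounds shown here, compound 4 was reported as not active, with no number, so no step from compound 3 to compound 4 can be read. No available evidence bears on this result. The compounds shown leave open how far compound 1 and compound 4, both without a number, lie from compound 2 and compound 3.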